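This account rests on a few compounds, and the source may have more. Where it says the series, first, only, none or still open, it means among the compounds named here.

Going by the values given here, compound 1 (`CCOc1cc(C(C)(C)C)ccc1C1=NC(c2ccc(Cl)cc2)C(c2ccc(Cl)cc2)N1C(=O)NCCCCCCCC(=O)Nc1ccccc1N`) gives 9910 nM in a functional assay on HCT-116 cells (Homo sapiens) for antiproliferative activity, read by CCK-8 assay, with a stated time of 72 h (a higher number here means a weaker inhibitor, a lower number a stronger inhibitor), and stands highest of the three numbers so far. Compound 2 (`CCOc1cc(C(C)(C)C)ccc1C1=NC(c2ccc(Cl)cc2)C(c2ccc(Cl)cc2)N1C(=O)N1CCN(CCCCCC(=O)NO)CC1`) gives 4030 nM and compound 3 (`CCOc1cc(C(C)(C)C)ccc1C1=NC(c2ccc(Cl)cc2)C(c2ccc(Cl)cc2)N1C(=O)N1CCN(Cc2ccc(C(=O)NO)cc2)CC1`) gives 2030 nM in this assay with both numbers lower than that of compound 1.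

Compound 4 (`CCOc1cc(C(C)(C)C)ccc1C1=NC(c2ccc(Cl)cc2)C(c2ccc(Cl)cc2)N1C(=O)NCCCCCC(=O)Nc1ccccc1N`) differs from compound 1 by (2-aminophenyl)carbamoyl in place of 2-((2-aminophenyl)carbamoyl)ethyl on a saturated chain carbon, five bonds along the chain from an amide-type nitrogen with (2-aminophenyl)carbamoyl in place of 2-((2-aminophenyl)carbamoyl)ethyl on a saturated chain carbon, five bonds along the chain from an amide-type nitrogen. Among the compounds with values here, the one measured step of a 2.0-fold lower number from compound 2 to compound 3 (0.30 log units; within the scatter) lies within the scatter and swaps a different group, so it bears on this change only indirectly. Within the data shown here, no measured pair alters the chain that carries the (2-aminophenyl)carbamoyl group, and no size can be read directly from the data. No change beyond the scatter is therefore expected in either direction in this assay and the expected step of a 1.4-fold lower number from compound 1 to compound 4 (0.15 log units; within the scatter) stays within it. For compound 4 the estimated value is 7000 nM with an expected range from 3000 nM to 15000 nM on this estimate.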

Compound 4, half-maximal inhibitory concentration: 21800 nM
Beside the measured number, compound 4's estimate is 3.1-fold (0.49 log units) below it, and the stated range ends below it.
By their numbers in this assay, from the lowest: compounds 3 and 2 (each within the scatter of the next); then compound 1; then compound 4.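

In this assay the chain carrying the (2-aminophenyl)carbamoyl group now has a measured change, and the shorter chain gives a 2.2-fold higher number from compound 1 to compound 4 (0.34 log units; beyond the scatter) as a modest step. This position therefore responds to the length of the chain, with the number moving up when (2-aminophenyl)carbamoyl replaces 2-((2-aminophenyl)carbamoyl)ethyl on a saturated chain carbon, five bonds along the chain from an amide-type nitrogen. Nothing available explains this step.

As far as these compounds go, two chain lengths give a direction only between these two compounds, so it remains open whether a longer chain than that of compound 1 would lower the number further or reverse the change. Also open, from the compounds shown here alone, is how a hydroxamic acid or a carboxylic acid at the end of this same chain would compare with the (2-aminophenyl)carbamoyl group.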